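The compounds below may be only part of what the source reports. "The series", "measured", "known", "first", "only" and "open" are said of these compounds alone.

Series notes. Compound 3 `CCCCc1oc2ccccc2c1C(=O)c1ccc(OCC(=O)Nc2ccccc2)cc1` gives 33600 nM in a functional assay on MCF7 cells (Homo sapiens) for antiproliferative activity, read by MTT assay, with a stated time of 24 h; on this read-out higher numbers stand for weaker inhibition and lower numbers for stronger inhibition. Compound 2 `CCCCc1oc2ccccc2c1C(=O)c1ccc(OCC(=O)N2CCOCC2)cc1` gives 34000 nM in this assay, and the two sit a 1.0-fold lower number from compound 2 to compound 3 (0.01 log units; within the scatter) apart. Compound 1 `CCCCc1oc2ccccc2c1C(=O)c1ccc(OCC(=O)N2CCCCC2)cc1` returns only a limit of the assay, > 50000 nM, which is the limit of > 50000 nM in this assay, at which 1 of the 3 values shown sits. Among the two real numbers compound 3 holds the lowest, with compound 2 nearest; against the limit of compound 1 the steps read an at least 1.4-fold lower number from compound 1 to compound 3 (0.17 log units; that floor lies within the scatter) and an at least 1.4-fold lower number from compound 1 to compound 2 (0.16 log units; that floor lies within the scatter), both floors lying within the scatter.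

Compound 4 `CCCCNC(=O)CCCOc1ccc(C(=O)c2c(CCCC)oc3ccccc23)cc1` is not yet measured. It differs from compound 3 by 2-(butylcarbamoyl)ethyl in place of phenylcarbamoyl on a saturated chain carbon bound to an oxygen on an aromatic ring. The amide exchanges already compared, piperidin-1-yl to morpholin-4-yl to anilino, leave the number essentially in place, so the change on the chain is expected to bring a 1.0-fold higher number from compound 3 to compound 4 (0.02 log units; within the scatter), no step beyond the scatter. Compound 4 is therefore estimated at 35000 nM, between 15000 nM and 80000 nM. Given the weak numbers across the series, a limit rather than a value remains a real possibility.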

Compound 4, half-maximal inhibitory concentration: > 50000 nM
Compound 4: only a limit was reported (the forecaster's own chance of this, stated with the estimate: 35%); middle value at least 1.4-fold (0.15 log units) away from the limit.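

Unlike the amide exchanges among compounds 1 to 3, this change also reaches the chain on the aromatic oxygen, and in this assay it yields only floors, an at least 1.4-fold higher number from compound 3 to compound 4 (0.17 log units; that floor lies within the scatter) and an at least 1.4-fold higher number from compound 2 to compound 4 (0.16 log units; that floor lies within the scatter) and so shows neither a real loss nor its absence. Compound 4 gives a limit rather than a number, so 3-(butylcarbamoyl)propyl at this position adds a second limit to the series: the limit of > 50000 nM in this assay, at which 2 of the 4 values shown sit. The step from compound 1 to compound 4 cannot be read, since both values are limits.

Open, as far as these compounds go, is whether the longer chain or the butyl amide governs the outcome, which a 3-(phenylcarbamoyl)propyl group would separate. Also open, from the compounds shown here alone, is whether a carboxylic acid or an amine in place of the amide would move the number beyond the scatter.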